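The compounds below may be only part of what the source reports. "The series", "measured", "known", "first", "only" and "open" are said of these compounds alone.

Measured compounds:
- Compound 1 `O=C1OC(Cc2nc(Cc3ccccc3)no2)c2ccccc21`: in an ADME assay on RAW264.7 cells (Mus musculus) for cytotoxicity, read by MTT assay, with a stated time of 24 h, in the absence of a further agent (on this read-out higher numbers stand for weaker inhibition and lower numbers for stronger inhibition), compound 1 gives > 40000 nM, which is a limit of the assay and not a number.
- Compound 2 `CCCCCCOc1ccc(C(O)C2OC(=O)c3c(OC)cc(OC)cc32)cc1`: in this assay compound 2 gives > 40000 nM, again a limit of the assay rather than a number.

Compound 2 therefore stands nowhere in particular on the numbers shown: its value is only a limit, and the one other value shown is a limit as well, both sitting at the same point (the limit of > 40000 nM in this assay, at which 2 of the 2 values shown sit). Going by the values given here, no pair of measured compounds differing in one place is available, so no measured step can be set against the change below.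

Compound 3 `COc1cc(OC)c2c(c1)C(C(O)c1ccc(OCc3ccc(Br)cc3)cc1)OC2=O` differs from compound 2 by 4-bromophenyl in place of pentyl on a saturated chain carbon bound to an oxygen on an aromatic ring. With both measured compounds at the limit, nothing in the data points to a direction for this change, and no step beyond the scatter is expected; the most likely outcome is that compound 3 also returns only a limit. Compound 3 is expected at 50000 nM, within 20000 nM to 150000 nM. The step that the limit leaves unreadable from compound 2 to compound 3 is accordingly estimated as none beyond the scatter.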

Compound 3, half-maximal inhibitory concentration: > 40000 nM
Compound 3: no number, only a limit (the forecaster's own chance of this, stated with the estimate: 80%); the middle value does not contradict the limit.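

No step from compound 2 to compound 3 can be read in this assay, as both give only a limit of the assay and not a number: the limit of > 40000 nM in this assay, at which 3 of the 3 values shown sit.

The compounds shown leave open whether any member of the series gives a number in this assay, and whether 4-bromophenyl in place of pentyl changes the read-out at all.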